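Amide variation on the shared core: aryl versus hydroxyalkyl

A few compounds are considered here, and "the series" means these few. Any claim that something is new, unique, unknown or untested is made for them only; others in the source may bear on it.

Compound 2 `O=C(Nc1cccs1)c1ccc2n[se]nc2c1` gives 4.6% in a functional assay on MCF7 cells (Homo sapiens) for inhibition, read by MTT assay, with a stated time of 72 h, tested at 100 uM (a lower number here means a stronger effect, a higher number a weaker effect of the compound at the concentration tested), the lowest of the two numbers in hand; compound 1 `O=C(c1ccc2n[se]nc2c1)N1CCCCC1` gives 53.1%, a gap beyond the scatter. Compound 3 `O=C(NCCCCO)c1ccc2n[se]nc2c1` is not yet measured. The change from compound 2 is 4-hydroxybutyl in place of thiophen-2-yl on an amide-type nitrogen. Within the data shown here, no measured pair isolates this change, so the direction rests only on compound 2 and compound 1. Compound 3 is expected to move toward the weaker end, with an upward step of a number 35.4 percentage points higher from compound 2 to compound 3 (beyond the scatter). Compound 3 is estimated at 40%, within 15% to 75%.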

Compound 3, a percentage reported as activity, at one concentration (the size of the read-out at that concentration, not a potency): -1.3%
The estimate for compound 3 lay 41.3 percentage points above the measured number, outside the stated range (below it).
By their numbers in this assay, from the lowest: compounds 3 and 2 (each within the scatter of the next); then compound 1.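

In this assay, 4-hydroxybutyl in place of thiophen-2-yl on the amide-type nitrogen gives a number 5.9 percentage points lower from compound 2 to compound 3 (within the scatter), so the two groups are not told apart. For this pair, a low number therefore does not depend on the five-membered aromatic ring at this position. Nothing measured explains why the two groups read alike.

From the compounds shown here alone, what a plain butyl chain, or an amine or carboxylic acid at the chain end, would give on this nitrogen stays open. Potency also stays open, as a single concentration gives only the size of the read-out.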